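The source may report more compounds than this note shows. Statements on the series, on what has been measured and on what is new or still open speak of the compounds shown alone.

Measured compounds:
compound 1 `O=C(/C=C/c1cn(-c2ccccc2)nc1-c1cccnc1)c1c[nH]c2ccccc12` — in a functional assay on HCT-116 cells (Homo sapiens) for inhibition, read by sulforhodamine B assay, with a stated time of 72 h (on this read-out higher numbers stand for weaker inhibition and lower numbers for stronger inhibition), compound 1 gives 6400 nM
compound 2 `O=C(/C=C/c1cn(-c2ccccc2)nc1-c1cccnc1)c1ccccc1` — compound 2 gives 2000 nM
compound 3 `COc1ccc(C(=O)/C=C/c2cn(-c3ccccc3)nc2-c2cccnc2)c(OC)c1OC` — compound 3 gives 1100 nM

Compound 3 carries the lowest number of the three in this assay. Its gap to compound 2 lies within the usual scatter, so the two cannot be ranked against each other; its gap to compound 1 lies beyond the scatter. For the measured compounds named here, the only step between two measured compounds is a 3.2-fold lower number from compound 1 to compound 2 (0.51 log units; beyond the scatter), a change of the whole aryl group on the carbonyl carbon.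

Compound 4 `COc1ccc(C(=O)/C=C/c2cn(-c3ccccc3)nc2-c2cccnc2)cc1OC` differs from compound 3 by hydrogen in place of methoxy on an aromatic carbon. Going by the values given here, no measured step touches a methoxy group on that ring, so the step from compound 1 to compound 2 gives no direct guide to this change. The change is small in the count of atoms removed, and the remaining ring keeps two methoxy groups. In this assay the step is therefore expected to stay within the scatter, if anything toward a slightly higher number. Compound 4 is expected to give about 1800 nM, within a range of 700 nM to 4500 nM. This estimate means an expected step of a 1.6-fold higher number from compound 3 to compound 4 (0.21 log units; within the scatter).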

Compound 4, half-maximal inhibitory concentration: 4300 nM
Beside the measured number, compound 4's estimate is 2.4-fold (0.38 log units) below it; measured number inside the range.
By their numbers in this assay, from the lowest: compounds 3 and 2 (each within the scatter of the next); then compounds 4 and 1 (each within the scatter of the next).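

In this assay, for the compounds shown here, the methoxy group on the aromatic carbon ortho to a large group, ortho to a methoxy group and meta to a methoxy group proves to count, since hydrogen in its place gives a 3.9-fold higher number from compound 3 to compound 4 (0.59 log units; beyond the scatter) and this is the only measured change of a single methoxy group on that ring. Two methoxy groups alone do not carry the ring to the level of compound 3: 3,4-dimethoxyphenyl in place of phenyl gives a 2.2-fold higher number from compound 2 to compound 4 (0.33 log units; beyond the scatter) and this step also lies beyond the scatter, so the numbers do not fall steadily with the count of methoxy groups across compound 2, compound 4 and compound 3. Against the 1H-indol-3-yl group, the same 3,4-dimethoxyphenyl group gives a 1.5-fold lower number from compound 1 to compound 4 (0.17 log units; within the scatter) within the scatter, which leaves those two compounds unranked.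

As far as these compounds go, whether a hydroxyl group, a fluorine atom or a longer chain such as ethoxy could stand on this carbon and keep the number of compound 3 remains open. Nothing available explains why this one methoxy group matters in this assay.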